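Adding a Chloro Group: What Three Measured Compounds Suggest

This account rests on a few compounds, and the source may have more. Where it says the series, first, only, none or still open, it means among the compounds named here.

Compound 1, `Cc1cc(O)c(C(=O)/C=C/c2ccc(Cl)cc2)c(-c2ccc(Cl)cc2)c1C(=O)/C=C/c1ccc(Cl)cc1`: 28000 nM
Compound 2, `Cc1cc(O)c(C(=O)/C=C/c2ccc(Cl)cc2)c(-c2ccccc2)c1C(=O)/C=C/c1ccc(Cl)cc1`: 10000 nM
Compound 3, `Cc1cc(O)c(C(=O)/C=C/c2cccc3ccccc23)c(-c2ccccc2)c1C(=O)/C=C/c1cccc2ccccc12`: 30000 nM

All three compounds were tested in a functional assay on MCF7 cells (Homo sapiens) for cytotoxicity, read by MTT assay, with a stated time of 24 h; a higher number here means a weaker inhibitor, a lower number a stronger inhibitor. Among the compounds with values here, compound 2 gives 10000 nM and is the one that differs from compound 1 in a single place: the change (chloro in place of hydrogen on an aromatic carbon). That change produced a 2.8-fold higher number from compound 2 to compound 1 (0.45 log units; beyond the scatter), so the chloro group made the compound a weaker inhibitor by a modest but real margin.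

Compound 3 carries a different set of side groups than compound 2; the difference between the two cores is not broken down here. In this assay compound 3 gives 30000 nM, a number that sits within the scatter of compound 1 and beyond it from compound 2.

Compound 4, `Cc1cc(O)c(C(=O)/C=C/c2cccc3ccccc23)c(-c2ccc(Cl)cc2)c1C(=O)/C=C/c1cccc2ccccc12`, has not been measured. It differs from compound 3 by chloro in place of hydrogen on an aromatic carbon, and the place of this change is described in exactly the same words as for the pair of compound 2 and compound 1, so it is the same change made on a different core. For compound 4 the expected step is a 2.5-fold higher number from compound 3 to compound 4 (0.40 log units; beyond the scatter), and this expectation rests on the measured step of a 2.8-fold higher number from compound 2 to compound 1 (0.45 log units; beyond the scatter). Within the data shown here, that step came from only one pair, and on another core. The range around the estimate is therefore kept wide. Compound 4 is expected to give about 75000 nM, with a likely range from 28000 nM to 200000 nM.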

Compound 4, half-maximal inhibitory concentration: 30000 nM
The estimate for compound 4 lay 2.5-fold (0.40 log units) above the measured number; the measured number falls inside the stated range.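

In this assay the same swap of phenyl to 4-chlorophenyl, now made on the second core, gives no change at the digits printed from compound 3 to compound 4 (within the scatter) and so does not repeat the earlier rise in the number. Set side by side, the two steps do not agree: the same change on two cores in this assay, a 2.8-fold higher number (0.45 log units; beyond the scatter) from compound 2 to compound 1 and no change at the digits printed (within the scatter) from compound 3 to compound 4, 2.8-fold (0.45 log units) apart, beyond the scatter of two such steps. Within the data shown here, this shows that the effect of adding this chloro group cannot simply be carried from one core to the other, since a step measured on one core did not predict the step on the second; it does not show why the two cores differ, and with only one pair on each core it cannot say how the same change would behave on any further core.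

The compounds shown have only hydrogen or chloro at this place, so it remains open whether a fluoro group, a bromo group, a methoxy group or an amine there would shift the number on either core. As far as these compounds go, it is also open how the chloro step would read on a core whose side groups carry something else, such as a carboxylic acid or a longer chain.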